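The source may hold more compounds than are shown below. What is called first, only, known or untested is meant among the compounds shown, and "the series" means these compounds.

Measured compounds:
compound 1 `CC(C)c1onc(-c2c(Cl)cccc2Cl)c1COc1ccc(N(C)Cc2ccc(OCCO)cc2)c(C(F)(F)F)n1`, 155 nM
compound 2 `CC(C)c1onc(-c2c(Cl)cccc2Cl)c1COc1cnc(N(C)Cc2ccc(C(=O)O)cc2)c(Cl)c1`, 120 nM

Both were tested in a functional assay on HEK293 cells for agonist activity at Bile acid receptor (Homo sapiens), read by a luciferase reporter; on this read-out higher numbers stand for an effect only at larger amounts of compound and lower numbers for an effect already at smaller amounts. Compound 1 gives 155 nM, and compound 2 gives 120 nM; the gap between these two numbers lies within the scatter, so the pair reads as alike. Compound 3 `CC(C)c1onc(-c2c(Cl)cccc2Cl)c1COc1cnc(N(C)Cc2cccc(C(=O)O)c2)c(Cl)c1` is not yet measured. It differs from compound 2 in one place: 3-carboxyphenyl in place of 4-carboxyphenyl on a saturated chain carbon bound to a nitrogen on an aromatic ring. Going by the values given here, no measured pair shows this move, so the expectation rests on the shared core alone. A small loss in this assay is expected, as a 2.1-fold higher number from compound 2 to compound 3 (0.32 log units; beyond the scatter). Compound 3 is expected at 250 nM, within 80 nM to 800 nM.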

Compound 3, half-maximal effective concentration: 61 nM
Compound 3: the middle estimate sits 4.1-fold (0.61 log units) above what was measured, outside the stated range (below it).
By their numbers in this assay, from the lowest: compounds 3, 2 and 1 (each within the scatter of the next, the first and the last beyond it).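

Exchanging 4-carboxyphenyl for 3-carboxyphenyl on a saturated chain carbon bound to a nitrogen on an aromatic ring leaves this assay essentially unchanged (a 2.0-fold lower number from compound 2 to compound 3 (0.29 log units; within the scatter)). The earlier compounds shown here held no such pair, and this one shows that the position accepts either carboxyphenyl isomer with the shared core otherwise intact. No measurement shown here offers an explanation for this result. As far as these compounds go, whether a tetrazole or a methyl ester in place of the carboxylic acid would give a similar number remains open, as does the behaviour of 3-carboxyphenyl on the core of compound 1.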